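Extending a Saturated Amide Chain with a Terminal Phenyl

This account rests on a few compounds, and the source may have more. Where it says the series, first, only, none or still open, it means among the compounds named here.

Measured compounds:
compound 1, `CCCCCC(=O)NCCCN1CCN(CCCNc2ccnc3cc(Cl)ccc23)CC1`: "not determined" (no result reported) in an ADME assay on L6 cells (Rattus norvegicus) for cytotoxicity; a lower number here means a stronger inhibitor, a higher number a weaker inhibitor
compound 2, `O=C(NCCCN1CCN(CCCNc2ccnc3cc(Cl)ccc23)CC1)c1cc(F)cc(F)c1`: 11600 nM
compound 3, `COc1cccc(C(=O)NCCCN2CCN(CCCNc3ccnc4cc(Cl)ccc34)CC2)c1`: 9300 nM

From the compounds shown here alone, compound 1 stands nowhere on the numbers: in this assay no result was reported for it, so its own level is unknown. Compound 4, `O=C(CCCCc1ccccc1)NCCCN1CCN(CCCNc2ccnc3cc(Cl)ccc23)CC1`, shares the whole of its core with compound 1 and differs in one place: phenyl in place of methyl on a saturated chain carbon, four bonds along the chain from a carbonyl carbon.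

For the measured compounds named here, only one measured step exists in this set, a 1.2-fold lower number from compound 2 to compound 3 (0.10 log units; within the scatter), and it exchanges one aryl group for another on the carbonyl carbon rather than touching a saturated chain, so it bears on the step from compound 1 to compound 4 only in a loose way. Its size shows that a change of the group on the amide carbonyl left the number essentially where it was, and the two measured values of compound 2 and compound 3 sit close together. Going by the values given here, no measured pair shows what a methyl-to-phenyl exchange on a saturated chain does here.

On that basis compound 4 is expected to fall near the region occupied by compound 2 and compound 3 in this assay, without a direction that can be supported. The estimate for compound 4 is 10000 nM, with a range from 3000 nM to 40000 nM.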

Compound 4, half-maximal inhibitory concentration: 9400 nM
Compound 4: the middle estimate sits 1.1-fold (0.03 log units) above what was measured; low and high end bracket the measured number.
By their numbers in this assay, from the lowest: compounds 3, 4 and 2 (each within the scatter of the next).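

In this assay the earlier numbers covered only aryl groups set directly on the carbonyl carbon, whereas compound 4 carries a 4-phenylbutyl group there, with the phenyl at the end of a saturated chain. That group gives a 1.0-fold higher number from compound 3 to compound 4 (0.00 log units; within the scatter) and a 1.2-fold lower number from compound 2 to compound 4 (0.09 log units; within the scatter) in this same assay, so the three compounds with numbers cannot be told apart, whether the group on the carbonyl carbon is an aryl ring or this chain. The exchange of methyl for phenyl itself cannot be read, since compound 1 has no number to set against compound 4, and nothing available offers an explanation for the closeness of these three values.

From the compounds shown here alone, it remains open whether an amine or a carboxylic acid in place of the phenyl, four bonds along the chain from the carbonyl carbon, would move the number beyond the scatter. A longer chain ending in the same phenyl, or a chlorine on that phenyl, is equally untested by the compounds shown here.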